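Trifluoromethyl to Methoxy on a Shared Core

This account rests on a few compounds, and the source may have more. Where it says the series, first, only, none or still open, it means among the compounds named here.

Compound 1 `Cc1nc(N2CCC(O)(C3CC3)CC2)nc2ccc(NC(=O)/C=C/c3ccc(C(F)(F)F)cc3)cc12`: 83 nM
Compound 2 `Cc1nc(N2CCC(N3C(=O)CCC3=O)CC2)nc2ccc(NC(=O)/C=C/c3ccc(OC(F)(F)F)cc3)cc12`: 35 nM

Both measured compounds were tested in a functional assay on CHO-K1 cells for antagonist activity at melanin-concentrating hormone receptor 1 (Homo sapiens), read by inositol phosphate accumulation, with stated times of 10 min and 45 min; a higher number here means a weaker inhibitor, a lower number a stronger inhibitor. Of the two numbers, compound 1 has the higher one, and the gap to compound 2 lies beyond the usual scatter of the method, so compound 2 is the stronger inhibitor of this pair.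

Compound 3 `COc1ccc(/C=C/C(=O)Nc2ccc3nc(N4CCC(O)(C5CC5)CC4)nc(C)c3c2)cc1` differs from compound 1 in a single place: methoxy in place of trifluoromethyl on an aromatic carbon. Among the measured compounds shown here, no measured pair shows this change, so its step is not known from the data. For the measured compounds named here, the only other group seen on this aromatic carbon, in compound 2, also carries fluorine, and the fluorine-bearing compounds hold both measured numbers. The expectation is therefore a modest move toward a weaker inhibitor in this assay, likely beyond the scatter but not large. Compound 3 is expected to give about 160 nM, within a range from 50 nM to 500 nM. The expected step is a 1.9-fold higher number from compound 1 to compound 3 (0.29 log units; within the scatter).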

Compound 3, half-maximal inhibitory concentration: 59 nM
Estimate against measurement, compound 3: 2.7-fold (0.43 log units) above; low and high end bracket the measured number.
By their numbers in this assay, from the lowest: compounds 2, 3 and 1 (each within the scatter of the next, the first and the last beyond it).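

Until now, every measured compound carried fluorine on this aromatic carbon, so the data could not show whether a group without fluorine would be accepted there. In this assay, methoxy in place of trifluoromethyl gives a 1.4-fold lower number from compound 1 to compound 3 (0.15 log units; within the scatter) and so shows that, on the core of compound 1, this position accepts a fluorine-free group with fewer heavy atoms and one hydrogen-bond acceptor. Nothing at hand explains why the two groups give values so close together.

Whether methoxy would behave the same way on the core of compound 2 remains an open question. The compounds shown also leave open how this position would respond to a chlorine atom, a nitrile, an amine, a carboxylic acid or a longer chain such as ethoxy.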